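The source may hold more compounds than are shown below. What is called first, only, known or untested is meant among the compounds shown, and "the series" means these compounds.

Measured so far:
compound 1 `N#Cc1cc(F)cc(C(=O)Nc2cccc(F)c2)c1`: 2160 nM
compound 2 `N#Cc1cc(F)cc(C(=O)Nc2ccc(F)cc2)c1`: > 10000 nM
compound 3 `Cc1cccc(NC(=O)c2cc(F)cc(C#N)c2)c1`: 122 nM

In an in vitro functional assay on HEK293-A cells for antagonist activity at metabotropic glutamate receptor 5 (Rattus norvegicus), read by calcium flux (on this read-out higher numbers stand for weaker inhibition and lower numbers for stronger inhibition), compound 1 gives 2160 nM. Compound 3 differs from compound 1 in one place, (methyl in place of fluoro on an aromatic carbon), and this change brought an 18-fold lower number from compound 1 to compound 3 (1.25 log units; beyond the scatter). Compound 2 is built from the same atoms as compound 1, joined differently; how the two cores differ is not broken down here. In this assay compound 2 gives > 10000 nM, which is a limit of the assay and not a number.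

Compound 4 `Cc1ccc(NC(=O)c2cc(F)cc(C#N)c2)cc1` has not yet been measured. It differs from compound 2 by methyl in place of fluoro on an aromatic carbon. Going by the values given here, this is the same kind of change as the one from compound 1 to compound 3, but not the same: there the place was meta to a large group, here it is para to a large group. It is expected that the step from compound 2 to compound 4 will be an at least 4.0-fold lower number from compound 2 to compound 4 (0.60 log units; beyond the scatter), resting on the earlier step of an 18-fold lower number from compound 1 to compound 3 (1.25 log units; beyond the scatter) and on the fact that compound 2 starts only from the limit (the limit of > 10000 nM in this assay, at which 1 of the 3 values shown sits). For compound 4 the expected value in this assay is 2500 nM, with a range from 500 nM to 10000 nM.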

Compound 4, half-maximal inhibitory concentration: > 30000 nM
Compound 4: only a limit was reported (the forecaster's own chance of this, stated with the estimate: 20%); middle value at least 12-fold (1.07 log units) away from the limit.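

Compound 2 gives > 10000 nM in this assay, which is a limit and not a number. Going by these compounds alone, compound 4 gives > 30000 nM, also a limit, so no step from compound 2 to compound 4 can be read. The compounds shown leave open how much methyl in place of fluoro changes inhibition when the place is para to a large group.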